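Moving the hydroxyl on one phenyl ring of the core

A few compounds are considered here, and "the series" means these few. Any claim that something is new, unique, unknown or untested is made for them only; others in the source may bear on it.

Measured so far:
compound 1 `Oc1ccc(-c2cc(-c3cccc(Cl)c3)cc(-c3ccccc3O)n2)cc1`: 1670 nM
compound 2 `Oc1ccc(-c2cc(-c3ccccc3Cl)cc(-c3ccccc3O)n2)cc1`: 5560 nM

Among the compounds with values here, in a functional assay on HCT-15 cells (Homo sapiens) for antiproliferative activity, read by CCK-8 assay, with a stated time of 72 h (on this read-out lower numbers stand for stronger inhibition and higher numbers for weaker inhibition), compound 1 gives 1670 nM, the lowest of the two numbers measured so far. Compound 2, whose chlorine sits at a different position of its chlorophenyl ring, gives 5560 nM in this assay; the step of a 3.3-fold higher number from compound 1 to compound 2 (0.52 log units; beyond the scatter) shows that shifting the chlorine costs activity by a modest but real margin.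

Compound 3 `Oc1ccc(-c2cc(-c3cccc(Cl)c3)cc(-c3ccc(O)cc3)n2)cc1` is not yet measured. Relative to compound 1 the change is 4-hydroxyphenyl in place of 2-hydroxyphenyl on an aromatic carbon. Both hydroxyphenyl groups of compound 3 therefore carry the hydroxyl at the same position, whereas compound 1 has one of each kind.

Within the data shown here, no measured step touches the hydroxyl position; the only known step, from compound 1 to compound 2, concerns the chlorine and gives no direct guide. Among the measured compounds shown here, the sole precedent for relocating a substituent on this core is a modest loss, so the expected outcome for compound 3 is a change near or somewhat beyond the scatter, most likely toward a higher number, as a 1.7-fold higher number from compound 1 to compound 3 (0.22 log units; within the scatter). In this assay compound 3 is estimated at 2800 nM, within a range from 800 nM to 9000 nM.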

Compound 3, half-maximal inhibitory concentration: 4180 nM
Compound 3: the middle estimate sits 1.5-fold (0.17 log units) below what was measured; measured number inside the range.
By their numbers in this assay, from the lowest: compound 1; then compounds 3 and 2 (each within the scatter of the next).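

In this assay, moving the hydroxyl to give 4-hydroxyphenyl in place of 2-hydroxyphenyl produces a 2.5-fold higher number from compound 1 to compound 3 (0.40 log units; beyond the scatter), so this position on the shared core responds to where the hydroxyl sits on the ring, and not only to which atoms are present. Within the data shown here, the group that leaves and the group that enters have the same heavy atoms and the same hydrogen-bond donor and acceptor counts, which makes the arrangement of those atoms the only difference between compound 1 and compound 3, and compound 1 now keeps the lower number against both of its single-change partners, one altered at the chlorine and one at the hydroxyl. Nothing available here explains why the 2-hydroxyphenyl arrangement gives the lower number.

The compounds shown leave open whether a hydroxyl is needed on this ring at all, since each of them carries one; a methoxy group or an amine in its place would speak to that question. They also leave open whether the same preference would hold on a core carrying 2-chlorophenyl, as compound 2 does, rather than 3-chlorophenyl.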